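The compounds below may be only part of what the source reports. "The series", "measured", "known", "first", "only" and "open" are said of these compounds alone.

Measured in a functional assay on Hs 683 cells (Homo sapiens) for inhibition, read by MTT assay, with a stated time of 72 h; a higher number here means a weaker inhibitor of growth, a lower number a stronger inhibitor of growth:

- compound 1 `CC(C)[Si]1(C(C)C)OC[C@H]2O[C@@H](n3ccc(=O)[nH]c3=O)[C@H](O)[C@@H]2O[Si](C(C)C)(C(C)C)O1`: 83000 nM
- compound 2 `Cc1cn([C@@H]2O[C@H](CO[Si](c3ccccc3)(c3ccccc3)C(C)(C)C)[C@@H](O)[C@H]2O)c(=O)[nH]c1=O`: 27000 nM

Of these two numbers, compound 2 has the lower, at 27000 nM, and the gap to compound 1 lies beyond the usual scatter. Compound 3 `CC(C)(C)[Si](OC[C@H]1O[C@@H](n2cnc3c(N)ncnc32)[C@H](O)[C@@H]1O)(c1ccccc1)c1ccccc1` differs from compound 2 in one group on a saturated ring carbon: a group of 10 heavy atoms (5 carbon, 5 nitrogen; one five-membered aromatic ring with 2 hetero atoms, one six-membered aromatic ring with 2 hetero atoms) in place of a group of 9 heavy atoms (5 carbon, 2 nitrogen, 2 oxygen; one six-membered aromatic ring with 2 hetero atoms), on a saturated ring carbon. Among the compounds with values here, no measured pair shows what such a swap does, so any forecast is uncertain. In this assay, no step beyond the scatter is expected, in either direction. The expected change is a 1.1-fold higher number from compound 2 to compound 3 (0.05 log units; within the scatter). The estimated value for compound 3 is 30000 nM, with an expected range of 10000 nM to 90000 nM.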

Compound 3, concentration for 50% growth inhibition: 46000 nM
Estimate against measurement, compound 3: 1.5-fold (0.19 log units) below; measured number inside the range.
By their numbers in this assay, from the lowest: compounds 2, 3 and 1 (each within the scatter of the next, the first and the last beyond it).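

In this assay, placing the two-ring group of 10 heavy atoms on the saturated ring carbon next to the ring oxygen, in place of the one-ring group of 9 heavy atoms, gives a 1.7-fold higher number from compound 2 to compound 3 (0.23 log units; within the scatter) and so stays within the scatter. This position therefore accepts a second aromatic ring without a clear change in growth inhibition. No measurement shown here explains this result.

Going by these compounds, whether a much smaller group at this carbon, such as an amine, would shift the number remains open.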